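Swapping Chloro for Methyl: Expected Stability of Compound 3

A few compounds are considered here, and "the series" means these few. Any claim that something is new, unique, unknown or untested is made for them only; others in the source may bear on it.

Of the compounds shown here, two have been tested in an ADME assay on microsomes from liver (Homo sapiens) for metabolic stability, with a stated time of 30 min; on this read-out higher numbers stand for a more stable compound and lower numbers for a less stable compound. Compound 1 `Cc1ccc2oc(NC(=O)CC3CCN(C(=O)OC(C)(C)C)CC3)nc2c1` gives 6%. Compound 2 `CC(=O)c1ccc(N2CCC(CC(=O)Nc3nc4cc(Cl)ccc4o3)CC2)cc1` gives 45%, the higher of the two numbers, and its gap to compound 1 lies beyond the usual scatter. Compound 3 `CC(=O)c1ccc(N2CCC(CC(=O)Nc3nc4cc(C)ccc4o3)CC2)cc1` has not been measured yet; it differs from compound 2 by methyl in place of chloro on an aromatic carbon. Among the measured compounds shown here, no measured pair shows this exact change, so its effect remains open. In this assay the expected step, a number 13 percentage points lower from compound 2 to compound 3 (beyond the scatter), is a modest fall that may still sit within the scatter. Compound 3 is therefore estimated at 32%, with a range from 12% to 55%.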

Compound 3, percent of the compound remaining: 53%
Compound 3: the middle estimate sits 21 percentage points below what was measured; the range from low to high includes it.
By their numbers in this assay, from the lowest: compound 1; then compounds 2 and 3 (each within the scatter of the next).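

In this assay, methyl in place of chloro on this aromatic carbon gives a number 8 percentage points higher from compound 2 to compound 3 (within the scatter) and so does not separate the two groups at this position. With methyl held on the aromatic carbon, 4-acetylphenyl in place of tert-butoxycarbonyl on the ring amine nitrogen gives a number 47 percentage points higher from compound 1 to compound 3 (beyond the scatter) as a change in one place, which the earlier pair, differing in two places, could not show. No measured evidence explains either step.

Going by these compounds, whether methoxy or an amine on that aromatic carbon would behave like methyl and chloro remains open. So does how a carboxylic acid on the phenyl ring in place of acetyl would read.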